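Ring methyl on compound 2: working notes

The source may hold more compounds than are shown below. What is called first, only, known or untested is meant among the compounds shown, and "the series" means these compounds.

Values in a physicochemical assay for solubility, at pH 7.4; a higher number here means a more soluble compound, a lower number a less soluble compound:
compound 1 `CNC1(C)CN(c2cc3c(cc2F)c(=O)c(C(=O)O)cn3C2CC2)C1` 0.7 ug/mL
compound 2 `CNC1CN(c2c(F)cc3c(=O)c(C(=O)O)cn(C4CC4)c3c2F)C1` 1.7 ug/mL
compound 3 `C[C@H]1[C@@H](N)CN1c1cc2c(cc1F)c(=O)c(C(=O)O)cn2C1CC1` 6.1 ug/mL

Of the three, compound 2 stands in the middle with 1.7 ug/mL, higher than compound 1 and lower than compound 3, and both gaps lie beyond the scatter.

Compound 4 `CN[C@H]1CN(c2c(F)cc3c(=O)c(C(=O)O)cn(C4CC4)c3c2F)[C@@H]1C` differs from compound 2 by methyl in place of hydrogen on a saturated ring carbon, next to the ring nitrogen.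

Going by the values given here, no measured step isolates this change. The nearest evidence is an 8.7-fold higher number from compound 1 to compound 3 (0.94 log units; beyond the scatter), but that step exchanges one whole group on an aromatic carbon for another. Compound 3 with 6.1 ug/mL does carry a methyl on a comparable ring carbon, yet its core differs from that of compound 2. A step of that size is therefore not assumed, and only a small rise is expected.

The estimate corresponds to an expected 1.5-fold higher number from compound 2 to compound 4 (0.17 log units; within the scatter), which would stay within the scatter. For compound 4 the expected value is 2.5 ug/mL, with an estimated range from 0.9 ug/mL to 7 ug/mL.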

Compound 4, solubility: 13.1 ug/mL
Estimate against measurement, compound 4: 5.2-fold (0.72 log units) below; the whole stated range lies below it.
By their numbers in this assay, from the lowest: compound 1; then compound 2; then compound 3; then compound 4.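

In this assay, methyl in place of hydrogen on a saturated ring carbon gives a 7.7-fold higher number from compound 2 to compound 4 (0.89 log units; beyond the scatter), and this is the only step shown that isolates this single change. The position, on the four-membered non-aromatic ring, next to the ring nitrogen and next to the ring atom that bears a methylamino group, is therefore not silent in this read-out: a single added carbon moves the number beyond the scatter. No measurement at hand accounts for the size of this step.

From the compounds shown here alone, whether an ethyl or a hydroxymethyl group on the same ring carbon would move the number in the same direction remains open. Also open, going by these compounds, is whether methyl in place of hydrogen at this position gives a step of similar size on the core of compound 1.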